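The compounds below may be only part of what the source reports. "The series", "measured", "known", "first", "only" and "open" are said of these compounds alone.

Measured so far:
- compound 1 `COc1ccccc1-c1ncc(C(=O)O)c(=O)[nH]1`: 10 mg/kg
- compound 2 `COc1ccc(-c2ncc(C(=O)O)c(=O)[nH]2)c(OC)c1`: 5 mg/kg
- compound 3 `CCOC(=O)c1cnc(-c2ccccc2OC)[nH]c1=O`: 10 mg/kg

In a functional assay on the whole organism (strain Sprague-Dawley) for inhibition, with Rattus norvegicus as the target, with a stated time of 10 min (on this read-out higher numbers stand for an effect only at larger amounts of compound and lower numbers for an effect already at smaller amounts), compound 3 gives 10 mg/kg, level with compound 1 at the digits shown, and compound 2 lies within the scatter of compound 3.

Compound 4 `CCOC(=O)c1cnc(-c2ccc(OC)cc2OC)[nH]c1=O` keeps the ethyl ester of compound 3 and takes methoxy in place of hydrogen on an aromatic carbon, meta to a methoxy group and para to a large group: methoxy in place of hydrogen on an aromatic carbon.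

For the measured compounds named here, the closest precedent is the same replacement among the acids, a 2.0-fold lower number from compound 1 to compound 2 (0.30 log units; within the scatter), which did not clear the scatter. The ester step, no change at the digits printed from compound 1 to compound 3 (within the scatter), suggests that the ester and the acid read alike in this assay, so the acid precedent may carry over. Going by the values given here, this rests on a single pair, and no measured pair tests the replacement on an ester.

The expected change is small and toward a lower number, not beyond the scatter: a 1.7-fold lower number from compound 3 to compound 4 (0.22 log units; within the scatter). For compound 4 the estimated value is 6 mg/kg, with an expected range of 2.5 mg/kg to 15 mg/kg.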

Compound 4, dose for 50% inhibition: 5 mg/kg
Compound 4: the middle estimate sits 1.2-fold (0.08 log units) above what was measured; measured number inside the range.
By their numbers in this assay, from the lowest: compounds 2, 4, 1 and 3 (each within the scatter of the next).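

In this assay, the replacement of hydrogen by methoxy on the aromatic carbon, meta to a methoxy group and para to a large group, can now be read on an ester as well as on an acid, with a 2.0-fold lower number from compound 3 to compound 4 (0.30 log units; within the scatter), and the two cores agree: the same change on two cores in this assay, a 2.0-fold lower number (0.30 log units; within the scatter) from compound 1 to compound 2 and a 2.0-fold lower number (0.30 log units; within the scatter) from compound 3 to compound 4, 1.0-fold (0.00 log units) apart, within the scatter of two such steps. The ethyl on the oxygen next to a carbonyl group now has a second pair, with no change at the digits printed from compound 2 to compound 4 (within the scatter), so the reading of acid and ester as alike no longer rests on one pair: the same change on two cores in this assay, no change at the digits printed (within the scatter) from compound 1 to compound 3 and no change at the digits printed (within the scatter) from compound 2 to compound 4, 1.0-fold (0.00 log units) apart, within the scatter of two such steps. Both changes stay within the scatter, so the agreement shows that they repeat across cores, not that either has an effect.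

The compounds shown carry only hydrogen or methoxy at this position, and only the acid or the ethyl ester at the carbonyl. From the compounds shown here alone, whether an amine or a longer alkoxy chain at this position, or an amide at the carbonyl, would move the result beyond the scatter remains open.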